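Changing the aryl group on the sulfonyl sulfur

The compounds below may be only part of what the source reports. "The series", "measured", "known", "first", "only" and "open" are said of these compounds alone.

In a functional assay on HepG2 cells (Homo sapiens) for antiproliferative activity, read by MTT assay, with a stated time of 48 h (on this read-out higher numbers stand for weaker inhibition and lower numbers for stronger inhibition), compound 1 (`Cc1ccc(S(=O)(=O)n2cc(/C=C/C(=O)c3ccncc3)c3ccccc32)cc1`) gives 44800 nM and compound 2 (`O=C(/C=C/c1cn(S(=O)(=O)c2ccccc2[N+](=O)[O-])c2ccccc12)c1ccncc1`) gives 31700 nM on the same read-out, so the two numbers available lie within the scatter of each other. Compound 3 (`O=C(/C=C/c1cn(S(=O)(=O)c2ccc(Cl)cc2)c2ccccc12)c1ccncc1`) carries 4-chlorophenyl in place of 2-nitrophenyl on a sulfonyl sulfur and has not yet been measured. Going by the values given here, the one measured change on this sulfur is 2-nitrophenyl in place of 4-methylphenyl (a 1.4-fold lower number from compound 1 to compound 2 (0.15 log units; within the scatter)), a step that stays within the scatter. A single small step is thin evidence, but it points to no particular direction, so no step beyond the scatter is expected in this assay here. The expected step is small (a 1.1-fold higher number from compound 2 to compound 3 (0.04 log units; within the scatter)) and stays within the scatter. Compound 3 is estimated at 35000 nM with 15000 nM to 75000 nM as the expected range.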

Compound 3, half-maximal inhibitory concentration: 35100 nM
Compound 3: the middle estimate sits 1.0-fold (0.00 log units) below what was measured, and the stated range covers the measured number.
By their numbers in this assay, from the lowest: compounds 2, 3 and 1 (each within the scatter of the next).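

On the sulfonyl sulfur, 4-chlorophenyl in place of 2-nitrophenyl stays within the scatter in this assay (a 1.1-fold higher number from compound 2 to compound 3 (0.04 log units; within the scatter)), and so does chloro in place of methyl on an aromatic carbon (a 1.3-fold lower number from compound 1 to compound 3 (0.11 log units; within the scatter)). The exchange of 2-nitrophenyl, with 9 heavy atoms and 2 hydrogen-bond acceptors, for 4-chlorophenyl, with 7 heavy atoms and 0 acceptors, therefore produces no step beyond the scatter, and 4-methylphenyl, 2-nitrophenyl and 4-chlorophenyl all lie within the scatter of one another. No measurement of any property of these groups accompanies the result.

Still open, as far as these compounds go, is whether a group carrying an amine or a carboxylic acid on the aryl ring, or a plain methyl in place of the aryl group on the sulfur, would give a step beyond the scatter. Changes elsewhere on the shared core also remain untested by these compounds.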